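Bromo for Ethynyl on the Pyridine of Compound 2

A few compounds are considered here, and "the series" means these few. Any claim that something is new, unique, unknown or untested is made for them only; others in the source may bear on it.

Compound 2 `C#Cc1ccnc(O[C@@H]2CC[C@@H](C)N(C(=O)c3ccccc3-n3nccn3)C2)c1` was tested in a functional assay on CHO-K1 cells for antagonist activity at Orexin receptor type 2 (Homo sapiens), read by FLIPR and calcium flux (on this read-out higher numbers stand for weaker inhibition and lower numbers for stronger inhibition), and gave 10 nM. Compound 1 `CC(C)OC(=O)c1ccccc1C(=O)N1C[C@H](Oc2cc(C#N)ccn2)CC[C@H]1C` gave 38 nM in this assay, so compound 2 holds the lower of the two numbers, and the gap to compound 1 lies beyond the scatter. Compound 3 `C[C@@H]1CC[C@@H](Oc2cc(Br)ccn2)CN1C(=O)c1ccccc1-n1nccn1` differs from compound 2 by bromo in place of ethynyl on an aromatic carbon. Compound 3 is expected to show a 1.5-fold higher number from compound 2 to compound 3 (0.18 log units; within the scatter), a change that stays within the scatter in either direction. Compound 3 is therefore estimated at 15 nM, with a range from 5 nM to 45 nM.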

Compound 3, half-maximal inhibitory concentration: 10 nM
The estimate for compound 3 lay 1.5-fold (0.18 log units) above the measured number; low and high end bracket the measured number.
By their numbers in this assay, from the lowest: compounds 2 and 3 (each within the scatter of the next); then compound 1.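

In this assay, bromo in place of ethynyl on the aromatic carbon opposite the ring nitrogen gives no change at the digits printed from compound 2 to compound 3 (within the scatter). This position therefore accepts a single bromine as well as the two-carbon ethynyl, so the triple bond is not needed to keep this read-out, something compounds 1 and 2 could not show because they differ in more than one place. Nothing available explains why the two groups read alike. The compounds shown leave open how an amine, a carboxylic acid or a longer chain would read at this carbon.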